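The source may hold more compounds than are shown below. What is called first, only, known or untested is meant among the compounds shown, and "the series" means these compounds.

Working notes on the series, starting from compound 1 (`CN(C)c1nc(N)nc2c1ncn2[C@H]1C[C@H](N=[N+]=[N-])[C@@H](CO)O1`). In an ADME assay on CCRF-CEM cells (Homo sapiens) for cytotoxicity, with a stated time of 5 days (a lower number here means a stronger inhibitor, a higher number a weaker inhibitor), compound 1 gives only a limit (> 100000 nM). Compound 2 (`CNc1nc(Cl)nc2c1ncn2[C@H]1C[C@H](N=[N+]=[N-])[C@@H](CO)O1`) also gives only a limit (> 100000 nM). Compound 3 (`CN(C)c1nc(Cl)nc2c1ncn2[C@H]1C[C@H](N=[N+]=[N-])[C@@H](CO)O1`) likewise gives only a limit (> 100000 nM). The whole measured set therefore stands at one ceiling: the limit of > 100000 nM in this assay, at which 3 of the 3 values shown sit.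

Compound 4 (`C=CCN(C)c1nc(N)nc2c1ncn2[C@H]1C[C@H](N=[N+]=[N-])[C@@H](CO)O1`) changes compound 1 as follows: vinyl in place of hydrogen on a saturated chain carbon bound to a nitrogen on an aromatic ring. This is vinyl in place of hydrogen on a saturated chain carbon bound to a nitrogen on an aromatic ring, so methyl becomes allyl.

For the measured compounds named here, two measured steps touch this part of the series, and neither has a readable size. The closer one, a change on the nitrogen, is a step that the two limits leave unreadable from compound 2 to compound 3. The other, a change elsewhere on the core, is a step that the two limits leave unreadable from compound 1 to compound 3. Neither supports a direction, so no shift beyond the scatter is expected in this assay.

The expected change is a number no higher from compound 1 to compound 4 (the limit leaves the size open). For compound 4 the estimate is 100000 nM, with an expected range of 40000 nM to 200000 nM.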

Compound 4, half-maximal inhibitory concentration: 27000 nM
Compound 4: the middle estimate sits 3.7-fold (0.57 log units) above what was measured, and the stated range ends above it.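

In this assay, for the compounds shown here, the change from methyl to allyl gives an at least 3.7-fold lower number from compound 1 to compound 4 (0.56 log units; beyond the scatter) and is the only step with a readable direction; the earlier steps cannot be read. The size stays a lower bound, as the number for compound 1 is only a limit. A change on a saturated chain carbon bound to a nitrogen on an aromatic ring is thus the one change shown that brings a compound off the ceiling shared by the rest of the set: the limit of > 100000 nM in this assay, at which 3 of the 4 values shown sit.

Still open, as far as these compounds go, is whether the double bond matters, which a saturated propyl group in the same place would test, and whether a longer chain or a benzyl group lowers the number further. Also open, from the compounds shown here alone, is whether allyl acts the same way with chloro in place of amino on the shared core.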